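Methylating the phenol of compound 2: an expected quiet step

The source may report more compounds than this note shows. Statements on the series, on what has been measured and on what is new or still open speak of the compounds shown alone.

Of the compounds shown here, two have been tested in a functional assay on RPMI-8226 cells (Homo sapiens) for inhibition, read by sulforhodamine B assay, with a stated time of 48 h, tested at 10 uM; on this read-out higher numbers stand for a weaker effect at the one concentration tested and lower numbers for a stronger effect. Compound 1 `COc1cc(Cl)cc(-c2nn(-c3cccc(NC(=O)c4cccc(C(F)(F)F)c4)c3)cc2-c2ccncc2)c1` gives 31.5% in this assay. Compound 2 `O=C(Nc1cccc(-n2cc(-c3ccncc3)c(-c3cc(O)cc(Cl)c3)n2)c1)c1cc(C(F)(F)F)cc(C(F)(F)F)c1` gives 32.1% in this assay. On these two numbers compound 2 stands beside compound 1: the gap between them lies within the scatter of repeated measurements, so no order between the two can be claimed.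

Compound 3 `COc1cc(Cl)cc(-c2nn(-c3cccc(NC(=O)c4cc(C(F)(F)F)cc(C(F)(F)F)c4)c3)cc2-c2ccncc2)c1` has not yet been measured. It differs from compound 2 in one place: methyl in place of hydrogen on an oxygen on an aromatic ring. Among the measured compounds shown here, no measured pair shows this change on its own. The step from compound 2 to compound 3 is expected to be a number 0.1 percentage points lower from compound 2 to compound 3 (within the scatter), nothing beyond the scatter, because compound 1 with its methoxy group gives 31.5% in this assay. Compound 3 is therefore estimated at 32%, within a range from 22% to 42%.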

Compound 3, a percentage reported as activity, at one concentration (the size of the read-out at that concentration, not a potency): 43.6%
Compound 3: middle estimate off by 11.6 percentage points, on the low side; measured number outside the range, above it.
By their numbers in this assay, from the lowest: compounds 1 and 2 (each within the scatter of the next); then compound 3.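

In this assay, hydroxy to methoxy on the aromatic ring is not the quiet change that compound 1 suggested: it gives a number 11.5 percentage points higher from compound 2 to compound 3 (beyond the scatter), a weaker effect at the one concentration tested. Trifluoromethyl in place of hydrogen on an aromatic carbon gives a step of similar size, a number 12.1 percentage points higher from compound 1 to compound 3 (beyond the scatter), so methoxy alone does not fix the read-out and the other substituents on the molecule also count. Nothing measured here explains either step.

The compounds shown leave open whether hydroxy to methoxy would give the same step in a compound carrying only one trifluoromethyl group. They also leave open how an amine or an ethoxy group in place of the hydroxy would read in this assay.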